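From Hydrogen to Methoxy on an Aromatic Carbon

The compounds below may be only part of what the source reports. "The series", "measured", "known", "first", "only" and "open" are said of these compounds alone.

Compound 1 `O=C1CCCCC/C1=C\c1ccccc1`: 110000 nM
Compound 2 `O=C1CCCCC/C1=C\c1ccc(Cl)cc1`: 43500 nM

In a functional assay on CCRF-CEM cells (Homo sapiens) for inhibition (on this read-out lower numbers stand for stronger inhibition and higher numbers for weaker inhibition), compound 1 gives 110000 nM as the higher of the two numbers. The change methoxy in place of hydrogen on an aromatic carbon leads from compound 1 to compound 3 `COc1cccc(/C=C2\CCCCCC2=O)c1` and puts methoxy in place of hydrogen on an aromatic carbon. The step of a 2.5-fold lower number from compound 1 to compound 2 (0.40 log units; beyond the scatter) is the only measured one that bears on this, and it is modest, with chloro entering rather than methoxy. A similarly modest move toward a lower number is therefore expected, though perhaps none beyond the scatter. For compound 3 the estimate is 65000 nM and is expected to fall between 28000 nM and 130000 nM. That estimate means a 1.7-fold lower number from compound 1 to compound 3 (0.23 log units; within the scatter) as the expected step.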

Compound 3, half-maximal inhibitory concentration: 128000 nM
Estimate against measurement, compound 3: 2.0-fold (0.29 log units) below; the range from low to high includes it.
By their numbers in this assay, from the lowest: compound 2; then compounds 1 and 3 (each within the scatter of the next).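

In this assay, methoxy on this aromatic carbon, meta to a group of 9 heavy atoms, leaves the number within the scatter (a 1.2-fold higher number from compound 1 to compound 3 (0.07 log units; within the scatter)). The modest drop seen with chloro (a 2.5-fold lower number from compound 1 to compound 2 (0.40 log units; beyond the scatter)) therefore does not carry over to methoxy at this place, although these two changes differ in the group that enters. From the compounds shown here alone, whether chloro, an amine or a carboxylic acid on this same carbon would shift the number remains open. Nothing measured here gives a reason for either step.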